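The source may report more compounds than this note shows. Statements on the series, on what has been measured and on what is new or still open speak of the compounds shown alone.

Measured compounds:
- compound 1, `O=C(O)c1ccccc1-c1ccccc1C(=O)NCCCCCCCn1cc(-c2cccnc2)nn1`: 38.5 nM
- compound 2, `NC(=O)c1ccccc1-c1ccccc1C(=O)NCCCCCCCn1cc(-c2cccnc2)nn1`: 87.9 nM
- compound 3, `CN(C)Cc1cn(-c2ccccc2C(=O)NCCCCCCCn2cc(-c3cccnc3)nn2)nn1`: 42.4 nM

These three share one core and differ only in the group attached to an aromatic carbon of the ring that carries the amide. In an assay for inhibition of Nicotinamide phosphoribosyltransferase (Mus musculus), read by fluorescence, with a stated time of 1 h, in the presence of a further agent that is not named here (on this read-out lower numbers stand for stronger inhibition and higher numbers for weaker inhibition), compound 2 gives the highest number of the three, that is the weakest inhibition shown. The steps to its two neighbours are both beyond the scatter but modest: a 2.3-fold higher number from compound 1 to compound 2 (0.36 log units; beyond the scatter) and a 2.1-fold lower number from compound 2 to compound 3 (0.32 log units; beyond the scatter).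

Compound 4, `O=C(NCCCCCCCn1cc(-c2cccnc2)nn1)c1ccccc1-n1cc(CN2CCCCC2)nn1`, has not yet been measured. It differs from compound 2 by 4-((piperidin-1-yl)methyl)-1H-1,2,3-triazol-1-yl in place of 2-carbamoylphenyl on an aromatic carbon. Among the compounds with values here, this change closely follows the one already seen between compound 2 and compound 3, where a triazole bearing a small amine-containing chain replaced the carbamoylphenyl group and the number fell beyond the scatter. Compound 4 carries the same kind of triazole, only with a piperidine in place of the dimethylamine on the methyl arm. Within the data shown here, no measured pair shows the effect of that swap alone, so the expectation rests on compound 3 and the step of a 2.1-fold lower number from compound 2 to compound 3 (0.32 log units; beyond the scatter).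

Compound 4 is therefore expected to land close to compound 3, with an estimated value of 45 nM (range 20 nM to 110 nM). This estimate means an expected step of a 2.0-fold lower number from compound 2 to compound 4 (0.29 log units; within the scatter).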

Compound 4, half-maximal inhibitory concentration: 17.1 nM
Compound 4: middle estimate off by 2.6-fold (0.42 log units), on the high side, outside the stated range (below it).
By their numbers in this assay, from the lowest: compound 4; then compounds 1 and 3 (each within the scatter of the next); then compound 2.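

In this assay, the swap on the arm of the triazole can now be read on its own: piperidin-1-yl in place of dimethylamino on a saturated chain carbon gives a 2.5-fold lower number from compound 3 to compound 4 (0.39 log units; beyond the scatter), so the amine at the end of this arm affects the result and is more than a passive detail. The 4-((piperidin-1-yl)methyl)-1H-1,2,3-triazol-1-yl group also separates from both phenyl-bearing compounds, with a 5.1-fold lower number from compound 2 to compound 4 (0.71 log units; beyond the scatter) and a 2.3-fold lower number from compound 1 to compound 4 (0.35 log units; beyond the scatter), whereas the dimethylamino version had only matched the acid, with a 1.1-fold higher number from compound 1 to compound 3 (0.04 log units; within the scatter) and thus no real difference. Nothing measured here explains why the piperidine gives the lower number.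

The compounds shown leave open whether this step belongs to piperidine in particular or would also come with another amine on the same arm, such as pyrrolidine, morpholine or diethylamine. As far as these compounds go, it also remains open how a triazole with a plain methyl group, carrying no amine at all, would compare with compound 3 and compound 4.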